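Shortening an Ethyl to a Methyl on the Piperazine

A few compounds are considered here, and "the series" means these few. Any claim that something is new, unique, unknown or untested is made for them only; others in the source may bear on it.

Of the compounds shown here, three with a shared core have been tested in a functional assay on RMS13 cells for antagonist activity at Urotensin-2 receptor (Homo sapiens), read by FLIPR and calcium flux, with a stated time of 1 h; on this read-out lower numbers stand for stronger inhibition and higher numbers for weaker inhibition. Compound 1 `CCN1CCN(c2cccc3c2CN([C@H](CCCNC(=O)c2cccs2)c2ccc(OC)c(OC)c2)C3=O)CC1` gives 140 nM. Compound 2 `CCN1CCN(c2cccc3c2CN([C@H](CCCN(C)S(=O)(=O)c2cccs2)c2ccc(OC)c(OC)c2)C3=O)CC1` gives 88 nM, and compound 3 `COc1ccc([C@@H](CCCN(C)S(=O)(=O)c2cccs2)N2Cc3c(cccc3N3CCN(C4CCC4)CC3)C2=O)cc1OC` gives 510 nM. Compound 2 thus holds the lowest number of the three: the step of a 1.6-fold lower number from compound 1 to compound 2 (0.20 log units; within the scatter) is too small to call a real difference, while the step of a 5.8-fold higher number from compound 2 to compound 3 (0.76 log units; beyond the scatter) is a clear worsening when cyclobutyl replaces ethyl on the amine nitrogen in the ring.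

Compound 4 `COc1ccc([C@@H](CCCN(C)S(=O)(=O)c2cccs2)N2Cc3c(cccc3N3CCN(C)CC3)C2=O)cc1OC` has not yet been measured. It differs from compound 2 by hydrogen in place of methyl on a saturated chain carbon bound to an amine nitrogen in a ring, so that 4-ethylpiperazin-1-yl becomes 4-methylpiperazin-1-yl. For the measured compounds named here, only the step from compound 2 to compound 3 touches this position, and there a larger group gave a higher number. Going the other way, to the smaller methyl, gives no reason to expect a large move, so compound 4 is expected to stay close to compound 2, with a 1.4-fold higher number from compound 2 to compound 4 (0.13 log units; within the scatter) as the estimated step. Compound 4 is therefore estimated at 120 nM, within a range of 45 nM to 320 nM, in this assay.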

Compound 4, half-maximal inhibitory concentration: 340 nM
Estimate against measurement, compound 4: 2.8-fold (0.45 log units) below; measured number above the stated range.
By their numbers in this assay, from the lowest: compounds 2 and 1 (each within the scatter of the next); then compounds 4 and 3 (each within the scatter of the next).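

In this assay, trimming the ethyl to a methyl gives a 3.9-fold higher number from compound 2 to compound 4 (0.59 log units; beyond the scatter) and so shows that the loss of a single carbon at this position is enough to move the number beyond the scatter. Earlier, only the larger cyclobutyl had shown a rise, so both the smaller and the larger group now sit above ethyl, while a 1.5-fold lower number from compound 3 to compound 4 (0.18 log units; within the scatter) leaves methyl and cyclobutyl impossible to tell apart. Nothing available explains why one carbon matters here.

On these data alone, it remains open whether a propyl or an isopropyl on the amine nitrogen in the ring would keep the low number of compound 2 or lose it as well. As far as these compounds go, it is also open whether ethyl would still beat methyl with the thiophene amide chain of compound 1.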